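This account rests on a few compounds, and the source may have more. Where it says the series, first, only, none or still open, it means among the compounds named here.

Measured compounds:
- Compound 1, `COc1ccc2ncc(S(=O)(=O)c3ccc(C)cc3)c(N3CCC(C)CC3)c2c1`: 90%
- Compound 2, `COc1cccc(S(=O)(=O)c2cnc3ccc(F)cc3c2N2CCC(C)CC2)c1`: 90%
- Compound 3, `COc1ccc2ncc(S(=O)(=O)c3cc(F)cc(F)c3)c(N3CCC(C)CC3)c2c1`: 30%

In an assay on isolated protein for displacement of a labelled ligand from metabotropic glutamate receptor 5 (Homo sapiens), with a stated time of 60 min, tested at 1 uM (a higher number here means more inhibition at the concentration tested (going by the name of the read-out), a lower number less inhibition), compound 3 stands lowest of the three numbers shown. Its nearest neighbour is compound 1, and the gap to compound 2 is of the same size, both lying beyond the scatter. Going by the values given here, the one measured step that reaches compound 3 is a number 60 percentage points lower from compound 1 to compound 3 (beyond the scatter), a large drop that accompanies the exchange of 4-methylphenyl for 3,5-difluorophenyl on the sulfonyl sulfur.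

Compound 4, `COc1cccc(S(=O)(=O)c2cnc3ccc(OC)cc3c2N2CCC(C)CC2)c1`, differs from compound 3 only at that same sulfonyl sulfur: 3-methoxyphenyl in place of 3,5-difluorophenyl on a sulfonyl sulfur. Two measured facts bear on this change. First, the step from compound 1 to compound 3 shows that replacing a substituted phenyl on the sulfonyl sulfur with 3,5-difluorophenyl cost most of the inhibition; going back to a different substituted phenyl may recover it. Second, compound 2 carries the very same 3-methoxyphenyl group on its sulfonyl sulfur, and although it differs from compound 4 elsewhere in the shared core, compound 2 reaches 90% in this assay.

A large upward step, a number 55 percentage points higher from compound 3 to compound 4 (beyond the scatter), is therefore expected. Compound 4 is estimated to give 85%, within a range from 65% to 100%.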

Compound 4, a percentage reported as inhibition, at one concentration (the size of the read-out at that concentration, not a potency): 0%
For compound 4 the middle estimate is 85 percentage points above the measured one, outside the stated range (below it).
By their numbers in this assay, from the lowest: compound 4; then compound 3; then compounds 1 and 2 (each within the scatter of the next).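

The 3-methoxyphenyl group on the sulfonyl sulfur does not secure inhibition by itself: in this assay, methoxy in place of fluoro on an aromatic carbon of the shared core gives a number 90 percentage points lower from compound 2 to compound 4 (beyond the scatter) and so shows that the outcome for this group depends on that second substituent. With the methoxy-bearing core held constant, 3-methoxyphenyl in place of 4-methylphenyl gives a number 90 percentage points lower from compound 1 to compound 4 (beyond the scatter) while 3-methoxyphenyl in place of 3,5-difluorophenyl gives a number 30 percentage points lower from compound 3 to compound 4 (beyond the scatter) and places 3-methoxyphenyl lowest of the three groups compared on that core, although 3,5-difluorophenyl had already brought a large loss. No measurement shown here offers an explanation for how the group on the sulfonyl sulfur and the substituent on the core relate to each other.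

The compounds shown leave open whether the fluoro core would also keep inhibition with 4-methylphenyl or 3,5-difluorophenyl on the sulfonyl sulfur, which would show how far the loss follows the methoxy group alone. They also leave open how chloro or a nitrile on that aromatic carbon would behave with 3-methoxyphenyl on the sulfonyl sulfur.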